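Aryl amine variation on the shared core

The compounds below may be only part of what the source reports. "The series", "measured", "known", "first", "only" and "open" are said of these compounds alone.

Compound 3 `CN1CCN(CCCOc2cccc3nc(Nc4ccc(F)c(F)c4)ccc23)CC1` gives 3140 nM in a functional assay on cells (Panel breast (Carcinoma cell lines), Homo sapiens) for inhibition, read by sulforhodamine B assay, with a stated time of 48 h (a lower number here means a stronger inhibitor of growth, a higher number a weaker inhibitor of growth), numerically the highest of the three numbers, though within the scatter of compound 2 `CN1CCN(CCCOc2cccc3nc(Nc4ccc(Cl)c(F)c4)ccc23)CC1` at 1840 nM and of compound 1 `CN1CCN(CCCOc2cccc3nc(Nc4ccc(Cl)c(C(F)(F)F)c4)ccc23)CC1` at 1690 nM. Compound 4 `CN1CCN(CCCOc2cccc3nc(Nc4cc(Cl)cc(Cl)c4)ccc23)CC1` differs from compound 3 by 3,5-dichlorophenyl in place of 3,4-difluorophenyl on a nitrogen on an aromatic ring. For the measured compounds named here, two measured steps bear on this change: a 1.7-fold higher number from compound 2 to compound 3 (0.23 log units; within the scatter), and a 1.9-fold higher number from compound 1 to compound 3 (0.27 log units; within the scatter); neither leaves the scatter. Replacing both fluorines by chlorines is therefore expected to give no more than a small step back toward lower numbers, a 1.7-fold lower number from compound 3 to compound 4 (0.22 log units; within the scatter), and possibly none beyond the scatter. Compound 4 is estimated at 1900 nM, with a range of 900 nM to 4000 nM.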

Compound 4, concentration for 50% growth inhibition: 2060 nM
Compound 4: the middle estimate sits 1.1-fold (0.04 log units) below what was measured; the range from low to high includes it.
By their numbers in this assay, from the lowest: compounds 1, 2, 4 and 3 (each within the scatter of the next).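

Replacing 3,4-difluorophenyl with 3,5-dichlorophenyl on this nitrogen gives no step beyond the scatter in this assay (a 1.5-fold lower number from compound 3 to compound 4 (0.18 log units; within the scatter)). The same holds against the other two aryl groups (a 1.1-fold higher number from compound 2 to compound 4 (0.05 log units; within the scatter); a 1.2-fold higher number from compound 1 to compound 4 (0.09 log units; within the scatter)), so all four halogen-bearing phenyl groups now stand within the scatter of one another, including one with a different arrangement of its two halogens. No evidence at hand accounts for this flat result.

Open, going by these compounds, is whether a phenyl carrying a methoxy group or a nitrile, or an unsubstituted phenyl, would leave this narrow band.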